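The source may hold more compounds than are shown below. What is called first, only, known or untested is meant among the compounds shown, and "the series" means these compounds.

In a physicochemical assay for solubility, read by mass spectrometry, in phosphate buffer, with a stated time of 24 h, at pH 3 (on this read-out higher numbers stand for higher solubility and lower numbers for lower solubility), compound 1 (`O=C(Nc1ccc(OC(F)(F)F)cc1)NC1CCN(C(=O)C2CCOCC2)CC1`) gives 1300 ug/mL while compound 2 (`Cc1occc1C(=O)N1CCC(NC(=O)Nc2ccc(C(F)(F)F)cc2)CC1`) gives 2.1 ug/mL and compound 3 (`Cc1ccoc1C(=O)N1CCC(NC(=O)Nc2ccc(C(F)(F)F)cc2)CC1`) gives 1.8 ug/mL in the same test. Compound 3 thus sits level with compound 2 and far short of compound 1. Compound 4 (`Cc1ccoc1C(=O)N1CCC(NC(=O)Nc2ccc(OC(F)(F)F)cc2)CC1`) differs from compound 3 by trifluoromethoxy in place of trifluoromethyl on an aromatic carbon. Going by the values given here, the single measured step, a 1.2-fold lower number from compound 2 to compound 3 (0.07 log units; within the scatter), lies within the scatter and concerns a carbonyl carbon, so it does not test this change. Among the compounds with values here, compound 1, at 1300 ug/mL in this test, also bears trifluoromethoxy, yet no measured step isolates that group. Compound 3, with 1.8 ug/mL as its reading, therefore remains the closest guide, and no change beyond the scatter is expected. The estimated step is a 1.2-fold lower number from compound 3 to compound 4 (0.08 log units; within the scatter) and points, if anywhere, slightly downward. Compound 4 is expected at 1.5 ug/mL with an estimated range from 0.5 ug/mL to 4.5 ug/mL in this assay once it is measured.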

Compound 4, solubility: 3.4 ug/mL
Compound 4: middle estimate off by 2.3-fold (0.36 log units), on the low side, within the range that was stated.
By their numbers in this assay, from the lowest: compounds 3, 2 and 4 (each within the scatter of the next); then compound 1.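

The change from trifluoromethyl to trifluoromethoxy on an aromatic carbon, para to a large group, gives a 1.9-fold higher number from compound 3 to compound 4 (0.28 log units; within the scatter), the first direct test of this position in this assay, and it does not move the reading beyond the scatter. Going by these compounds alone, with trifluoromethoxy on both sides, the one change of 3-methylfuran-2-yl in place of oxan-4-yl on a carbonyl carbon gives a 380-fold lower number from compound 1 to compound 4 (2.58 log units; beyond the scatter), so trifluoromethoxy appears with both a high and a low reading, and the large step belongs to the carbonyl substituent. No measurement shown here accounts for the size of either step.

From the compounds shown here alone, it remains open whether a nitrile or a methoxy group on this aromatic carbon would also stay within the scatter of compound 3. Also open, going by these compounds, is how an amine or a carboxylic acid in place of 3-methylfuran-2-yl on the carbonyl carbon would read.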